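This account rests on a few compounds, and the source may have more. Where it says the series, first, only, none or still open, it means among the compounds named here.

Working notes on the aryl enone acid series in a functional assay on LS174T cells (Homo sapiens) for inhibition, read by MTT assay, with a stated time of 72 h; on this read-out higher numbers stand for weaker inhibition and lower numbers for stronger inhibition. Three compounds have numbers. Compound 1, `Cc1cc(C2CCCCC2)c(C)cc1C(=O)/C=C/C(=O)O`, gives 6640 nM in this assay. Compound 2, `CC(C)(C)c1ccc(C(=O)/C=C/C(=O)O)cc1`, gives 8740 nM in this assay. Compound 3, `CCc1c(C(=O)/C=C/C(=O)O)cc(C(C)C)cc1C(C)C`, gives 12400 nM in this assay. Compound 2 sits within the scatter of both compound 1 and compound 3, so on the numbers shown the three compounds cannot be told apart; the whole measured set occupies a narrow band, and no single change between two measured compounds has been isolated.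

Compound 4, `O=C(O)/C=C/C(=O)c1ccc(F)cc1`, has not been measured in this assay. It differs from compound 2 in one place: fluoro in place of tert-butyl on an aromatic carbon. The measured compounds all carry alkyl substitution on the aromatic ring, so nothing here says how a fluoro at that place behaves.

Given that, the step from compound 2 to compound 4 is expected to be modest; a small move toward a higher number is estimated, a 1.5-fold higher number from compound 2 to compound 4 (0.17 log units; within the scatter), but a result inside the scatter would not surprise. Compound 4 is therefore expected to give about 13000 nM in this assay, with a range from 4500 nM to 40000 nM.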

Compound 4, half-maximal inhibitory concentration: 33800 nM
The estimate for compound 4 lay 2.6-fold (0.41 log units) below the measured number, within the range that was stated.
By their numbers in this assay, from the lowest: compounds 1, 2 and 3 (each within the scatter of the next); then compound 4.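

In this assay, within the data shown here, the aromatic carbon para to a group of 7 heavy atoms now has a step that can be read, where the earlier compounds offered no single change to isolate: fluoro in place of tert-butyl gives a 3.9-fold higher number from compound 2 to compound 4 (0.59 log units; beyond the scatter) and so lies outside the narrow band in which the first three compounds could not be told apart. This place is therefore not indifferent to what it carries, since exchanging a group of 4 heavy atoms for one of a single heavy atom shifts the number beyond the scatter, at least for this one pair. Nothing at hand bears on what lies behind the size of this step, and it stands as an observation only.

On these data alone, a single pair cannot separate the loss of the tert-butyl from the gain of the fluoro, so it remains open whether plain hydrogen, a chlorine or a methyl at this place would stay with compound 2 or with compound 4. Also open, as far as these compounds go, is how a longer chain, a methoxy or an amine would behave at the same carbon.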